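A few compounds are considered here, and "the series" means these few. Any claim that something is new, unique, unknown or untested is made for them only; others in the source may bear on it.

Compound 1 `CC(C)c1n[nH]c2c(NCc3ccc(-c4ccccn4)cc3)nc(SCC(O)CN)nc12`: 55 nM
Compound 2 `CSCCSc1nc(NCc2ccc(-c3ccccn3)cc2)c2[nH]nc(C(C)C)c2n1`: 975 nM

In a functional assay on HT cells (Homo sapiens) for antiproliferative activity, read by fluorescence, with a stated time of 72 h (on this read-out higher numbers stand for weaker inhibition of growth and lower numbers for stronger inhibition of growth), compound 2 has the higher of the two numbers, at 975 nM. Compound 3 `CC(=O)NCCSc1nc(NCc2ccc(-c3ccccn3)cc2)c2[nH]nc(C(C)C)c2n1` changes it in one place: acetamido in place of methylsulfanyl on a saturated chain carbon, two bonds along the chain from a sulfur, with acetamido in place of methylsulfanyl on a saturated chain carbon, two bonds along the chain from a sulfur. Within the data shown here, the only measured step that bears on this is large: an 18-fold higher number from compound 1 to compound 2 (1.25 log units; beyond the scatter). It involves the same sulfur-bound chain, but a different group, so only a partial return towards compound 1 is expected. The expected change is a 2.2-fold lower number from compound 2 to compound 3 (0.34 log units; beyond the scatter). Compound 3 is estimated at 450 nM, with an expected range of 130 nM to 1500 nM.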

Compound 3, concentration for 50% growth inhibition: 71 nM
Compound 3: the middle estimate sits 6.3-fold (0.80 log units) above what was measured; the measured number lies below the stated range.
By their numbers in this assay, from the lowest: compounds 1 and 3 (each within the scatter of the next); then compound 2.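

In this assay, the end of the sulfur-bound chain matters strongly: acetamido in place of methylsulfanyl gives a 14-fold lower number from compound 2 to compound 3 (1.14 log units; beyond the scatter) at this position. Among these compounds, the 2-amino-1-hydroxyethyl group of compound 1 is also not the only group that gives a low number, since a 1.3-fold higher number from compound 1 to compound 3 (0.11 log units; within the scatter) separates it from the acetamidomethyl group. From the compounds shown here alone, whether a carboxylic acid at this place, or a longer chain carrying the acetamido, would give a similarly low number remains open. Nothing measured here explains the large step from methylsulfanyl to acetamido.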